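The compounds below may be only part of what the source reports. "The series", "measured", "known", "first", "only" and "open" are said of these compounds alone.

Measured compounds in a functional assay on HEK293 cells for agonist activity at probable G-protein coupled receptor 27 (Homo sapiens), read by a luciferase reporter and beta-arrestin recruitment, with a stated time of 10 min; on this read-out higher numbers stand for larger maximal responses and lower numbers for smaller maximal responses:
- compound 1, `Cc1cc(Cl)ccc1C(=O)Nc1ccc(S(=O)(=O)Nc2ccccc2)cc1`, 123%
- compound 2, `O=C(Nc1ccc(S(=O)(=O)Nc2ccccc2)cc1)c1ccc(Br)cc1F`, 67%
- compound 3, `N#Cc1ccc(C(=O)Nc2ccc(S(=O)(=O)Nc3ccccc3)cc2)c(F)c1`, 29%

Compound 3 stands lowest of the three values in this assay. Its nearest neighbour is compound 2, with the step of a number 38 percentage points lower from compound 2 to compound 3 (beyond the scatter) separating them; compound 1 lies furthest off, by the step of a number 94 percentage points lower from compound 1 to compound 3 (beyond the scatter). Both steps are beyond the scatter.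

Compound 4, `O=C(Nc1ccc(S(=O)(=O)Nc2ccccc2)cc1)c1ccc(Cl)cc1Br`, is not yet measured. It differs from compound 3 as follows: 2-bromo-4-chlorophenyl in place of 4-cyano-2-fluorophenyl on a carbonyl carbon.

Among the measured compounds shown here, two measured steps bear on this change. Going from a 4-chloro-2-methylphenyl to a 4-bromo-2-fluorophenyl on the carbonyl carbon gave a number 56 percentage points lower from compound 1 to compound 2 (beyond the scatter); swapping bromo for cyano on the aromatic carbon gave a number 38 percentage points lower from compound 2 to compound 3 (beyond the scatter). Compound 4 carries a halogen in place of the nitrile, and a second halogen where compound 3 carries fluorine, so it is closer in kind to compound 1 and compound 2 than to compound 3. A large upward step in this assay is therefore expected, roughly reversing the drop seen from compound 2 to compound 3 and possibly more.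

Compound 4 is estimated at 90% in this assay, within a range of 50% to 130%. This estimate corresponds to an expected step of a number 61 percentage points higher from compound 3 to compound 4 (beyond the scatter).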

Compound 4, largest response reached (Emax), in percent of the reference or control that the assay uses: 123%
Beside the measured number, compound 4's estimate is 33 percentage points below it, and the stated range covers the measured number.
By their numbers in this assay, from the lowest: compound 3; then compound 2; then compounds 1 and 4 (each within the scatter of the next).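

Carrying 2-bromo-4-chlorophenyl on the carbonyl carbon gives a number 94 percentage points higher from compound 3 to compound 4 (beyond the scatter) in this assay, which shows that a change at this one place spans the whole range of the series so far. Among the compounds shown here, the step of a number 56 percentage points higher from compound 2 to compound 4 (beyond the scatter) adds that a bromo on the aryl group does not by itself fix the response, as 4-bromo-2-fluorophenyl and 2-bromo-4-chlorophenyl both carry one, while no change at the digits printed from compound 1 to compound 4 (within the scatter) shows that bromo in place of methyl on an aromatic carbon is the first change here that leaves the read-out unmoved. Nothing available explains any of these steps.

Still open, going by these compounds, is whether the response of compound 4 in this assay survives a methoxy group or an amine in place of its bromo or its chloro, or a saturated ring such as cyclohexyl in place of the whole aryl group on the carbonyl carbon. Also open, on these data alone, is how far the response depends on the core of compound 4, for instance with a carboxylic acid placed on it.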